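The source may report more compounds than this note shows. Statements on the series, on what has been measured and on what is new or still open speak of the compounds shown alone.

Of the compounds shown here, three of one shared core have so far been measured in a functional assay (Mus musculus) for inhibition, with a stated time of 5 days; a lower number here means a stronger inhibitor, a higher number a weaker inhibitor. Compound 1, with the structure `O=C(O)/C=C/c1cn(-c2ccc(O)cc2)nc1-c1ccc(O)cc1`, reaches only a limit in this assay and gives > 100000 nM; a value of this sort is a boundary of the assay and not a number, and the limit of > 100000 nM in this assay, at which 1 of the 3 values shown sits, records it. Compound 2, with the structure `O=Cc1cn(-c2ccc(O)cc2)nc1-c1cc(O)ccc1O`, gives 43000 nM in this assay. Compound 3, with the structure `CCOC(=O)/C=C/c1cn(-c2ccc(O)cc2)nc1-c1ccccc1`, gives 29000 nM in this assay, which is the lowest of the two numbers recorded; the nearest number belongs to compound 2 and sits within the scatter, so no order between compound 2 and compound 3 can be read from them.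

Compound 4, with the structure `O=Cc1cn(-c2ccc(O)cc2)nc1-c1ccccc1`, has not yet been measured in this assay. It differs from compound 3 in one place: formyl in place of 2-(ethoxycarbonyl)ethenyl on an aromatic carbon. Going by the values given here, no step between measured compounds isolates this exchange, so its size is not known. Compound 2 carries the same formyl group on a differently substituted core and gives 43000 nM, a number within the scatter of compound 3. On that basis compound 4 is expected to stay within the scatter of compound 3, with a step of a 1.4-fold higher number from compound 3 to compound 4 (0.14 log units; within the scatter). Compound 4 is therefore estimated at 40000 nM, with a range from 12000 nM to 130000 nM.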

Compound 4, half-maximal inhibitory concentration: > 100000 nM
Compound 4: a limit, no number; the forecaster's own chance of this, stated with the estimate: 25%; at least 2.5-fold (0.39 log units) between middle value and limit.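

Going by these compounds alone, until this result, nothing isolated what the group at this position contributes in this assay. On the aromatic carbon next to the ring atom that bears a phenyl group, formyl in place of 2-(ethoxycarbonyl)ethenyl gives an at least 3.4-fold higher number from compound 3 to compound 4 (0.53 log units; beyond the scatter), so this position is not indifferent to the change. Compound 4 stands at a limit of the assay and not at a number, so the step gives only a lower bound on the size of the change, and compound 4 shares that limit with compound 1: the limit of > 100000 nM in this assay, at which 2 of the 4 values shown sit.

The compounds shown leave open which part of the 2-(ethoxycarbonyl)ethenyl group carries the difference: the ethyl ester, the double bond or the length of the chain. They also do not tell how an amide, an amine or a longer chain on this carbon would read in this assay.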